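A few compounds are considered here, and "the series" means these few. Any claim that something is new, unique, unknown or untested is made for them only; others in the source may bear on it.

Measured so far:
compound 1 `NS(=O)(=O)Oc1ccc2c(c1)CN(C(=O)c1cccc(N3CCC(Cc4ccccc4)CC3)c1)CC2` — 1.4%
compound 2 `CN(CCCN1CCCCC1)c1ccc(C(=O)N2CCc3ccc(OS(N)(=O)=O)cc3C2)cc1` — 17.4%

In an assay on HEK293 cells for inhibition of Steryl-sulfatase (Homo sapiens), tested at 0.1 uM (a higher number here means a stronger effect of the compound at the concentration tested, a lower number a weaker effect), compound 2 gives 17.4% and stands highest of the two numbers. Compound 1 gives 1.4%, a gap beyond the scatter. Compound 3 `CN(C)CCN(CCN(C)C)c1ccc(C(=O)N2CCc3ccc(OS(N)(=O)=O)cc3C2)cc1` differs from compound 2 in one place: bis(2-(dimethylamino)ethyl)amino in place of methyl(3-(piperidin-1-yl)propyl)amino on an aromatic carbon. For the measured compounds named here, no measured pair isolates this change, so the size of the step is open. A step within the scatter is expected, with a small downward lean: the step from compound 2 to compound 3 is estimated as a number 4.4 percentage points lower from compound 2 to compound 3 (within the scatter). Compound 3 is expected to give 13% in this assay, between 2% and 30%.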

Compound 3, a percentage reported as inhibition, at one concentration (the size of the read-out at that concentration, not a potency): 3.8%
Beside the measured number, compound 3's estimate is 9.2 percentage points above it, and the stated range covers the measured number.
By their numbers in this assay, from the lowest: compounds 1 and 3 (each within the scatter of the next); then compound 2.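

In this assay the group on an aromatic carbon para to a large group proves sensitive to its make-up: bis(2-(dimethylamino)ethyl)amino in place of methyl(3-(piperidin-1-yl)propyl)amino gives a number 13.6 percentage points lower from compound 2 to compound 3 (beyond the scatter) even though both groups hold the same number of heavy atoms. The exchange removes the six-membered non-aromatic ring and adds a nitrogen. Nothing available explains the step.

Still open, on these data alone, is whether the loss of the ring or the added nitrogen accounts for the step. A methyl(3-(dimethylamino)propyl)amino group at this position would separate the two.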